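The source may report more compounds than this note shows. Statements on the series, on what has been measured and on what is new or still open speak of the compounds shown alone.

In a functional assay on Caco-2 cells (Homo sapiens) for antiproliferative activity, read by sulforhodamine B assay, with a stated time of 48 h (on this read-out lower numbers stand for stronger inhibition and higher numbers for weaker inhibition), compound 1 (`COc1cc(NC(C)CCCN2C(=O)[C@H](C)NC2(C)C)c2ncccc2c1`) gives 71000 nM and compound 2 (`COc1cc(NC(C)CCCNC(=O)CN2C(=O)[C@H](C)NC23CCCCC3)c2ncccc2c1`) gives 74700 nM while compound 3 (`COc1cc(NC(C)CCCNC(C)=O)c2ncccc2c1`) gives 46000 nM and these three values lie within the scatter of one another. Compound 3 therefore holds no distinct place among them. Compound 4 (`COc1cc(NC(C)CCCNC(=O)C2CCCN2C(=O)[C@@H](C)N)c2ncccc2c1`) keeps the core of compound 3 and alters only the group on the carbonyl carbon, where the change is 1-((1-aminoethyl)carbonyl)pyrrolidin-2-yl in place of methyl on a carbonyl carbon and amounts to 1-((1-aminoethyl)carbonyl)pyrrolidin-2-yl in place of methyl. Among the compounds with values here, no measured step makes this exact change. The nearest evidence is the step of a 1.5-fold lower number from compound 1 to compound 3 (0.19 log units; within the scatter) and it stays within the scatter. Compound 2, which also has a larger group on that carbonyl carbon, sits at 74700 nM and so shows no clear departure from compound 3. No step beyond the scatter is therefore expected in this assay and the estimated step is a 1.2-fold higher number from compound 3 to compound 4 (0.08 log units; within the scatter) in this series. For compound 4 the estimated value is 55000 nM with an expected range from 22000 nM to 110000 nM as its likely span.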

Compound 4, half-maximal inhibitory concentration: 64000 nM
For compound 4 the middle estimate is 1.2-fold (0.07 log units) below the measured one; the measured number falls inside the stated range.
By their numbers in this assay, from the lowest: compounds 3, 4, 1 and 2 (each within the scatter of the next).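

In this assay, 1-((1-aminoethyl)carbonyl)pyrrolidin-2-yl in place of methyl on a carbonyl carbon gives a 1.4-fold higher number from compound 3 to compound 4 (0.14 log units; within the scatter). Within the data shown here, this is the first measured step at this position, and it shows that a group of 10 heavy atoms, with a five-membered non-aromatic ring, 1 hydrogen-bond donor and 2 hydrogen-bond acceptors, can replace a single methyl carbon here without a step beyond the scatter. No measurement at hand gives a reason for this result.

The compounds shown leave open whether a carboxylic acid or a phenyl ring on this carbonyl carbon would give a step beyond the scatter. They also leave open whether the opposite configuration at the defined stereocentre of the entering group would change the number.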